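This account rests on a few compounds, and the source may have more. Where it says the series, first, only, none or still open, it means among the compounds named here.

Compound 1, `CC1=C(C(=O)NC(C)C)C(c2ccco2)NC(=O)N1`: 2%
Compound 2, `CCNC(=O)C1=C(C)NC(=O)NC1c1cccs1`: 1%
Compound 3, `CC1=C(C(=O)NC(C)C)C(c2cccs2)NC(=O)N1`: 40%

In an assay on membranes from HEK293 cells for displacement of a labelled ligand from adenosine receptor A2b (Homo sapiens), read by scintillation counting, with a stated time of 30 min, tested at 1 uM (a lower number here means less inhibition, a higher number more inhibition at the concentration tested (going by the name of the read-out)), compound 3 gives 40%, the highest of the three numbers, while compound 1 gives 2% and compound 2 gives 1%. The two steps that lead to compound 3 are both large: a number 38 percentage points higher from compound 1 to compound 3 (beyond the scatter) and a number 39 percentage points higher from compound 2 to compound 3 (beyond the scatter). Compound 4, `CC1=C(C(=O)OC2CCCC2)C(c2cccs2)NC(=O)N1`, differs from compound 3 by cyclopentyloxy in place of isopropylamino on a carbonyl carbon. Neither measured step touches the carbonyl carbon, so no direct guide exists for this change, though both show that a single alteration on this core can move the number far. A moderate drop is expected, a number 15 percentage points lower from compound 3 to compound 4 (beyond the scatter), for compound 4. The estimate for compound 4 is 25%, with a range from 5% to 60%.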

Compound 4, a percentage reported as inhibition, at one concentration (the size of the read-out at that concentration, not a potency): 1%
Compound 4: the middle estimate sits 24 percentage points above what was measured, outside the stated range (below it).
By their numbers in this assay, from the lowest: compounds 2, 4 and 1 (each within the scatter of the next); then compound 3.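

Cyclopentyloxy in place of isopropylamino on the carbonyl carbon gives a number 39 percentage points lower from compound 3 to compound 4 (beyond the scatter), the first sign that this place matters as much as the two places already changed. The same group in place of ethylamino gives no change at the digits printed from compound 2 to compound 4 (within the scatter), so among these three thiophen-2-yl compounds only isopropylamino keeps a clear number. Nothing available explains this. On these data alone, it stays open whether the change follows the oxygen or the ring, which cyclopentylamino or isopropyloxy at this carbon could separate. As far as these compounds go, whether tert-butylamino would go beyond isopropylamino is also open.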